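Ester chain variation in the dihydropyridine set

A few compounds are considered here, and "the series" means these few. Any claim that something is new, unique, unknown or untested is made for them only; others in the source may bear on it.

Two compounds have numbers in a functional assay on HEK293 cells for antagonist activity at Voltage-dependent L-type calcium channel subunit alpha-1C (Oryctolagus cuniculus), read by FLIPR (a lower number here means a stronger inhibitor, a higher number a weaker inhibitor), so far. Compound 1 `CCCC1=C(C(=O)OCC)C(c2cccc([N+](=O)[O-])c2)C(C(=O)OCC)=C(C)N1` gives 18 nM in this assay. Compound 2 `COC(=O)C1=C(C)NC(C)=C(C(=O)OCC(C)[N+](=O)[O-])C1c1cccc([N+](=O)[O-])c1` gives 108 nM in this assay, the highest of the two numbers; its nearest neighbour, compound 1, sits well beyond the scatter at the lower end. For the measured compounds named here, no two measured compounds differ in a single place, so no step within the set can be read directly.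

Compound 3 `COC(=O)C1=C(C)NC(C)=C(C(=O)OCCCCc2ccccc2)C1c1cccc([N+](=O)[O-])c1` is not yet measured. It differs from compound 2 as follows: 3-phenylpropyl in place of 1-nitroethyl on a saturated chain carbon bound to an oxygen next to a carbonyl group. Going by the values given here, the only guide is that compound 1, whose esters carry no nitro group, gives 18 nM in this assay. On that basis compound 3 is expected to move towards a lower number, with a step of a 2.7-fold lower number from compound 2 to compound 3 (0.43 log units; beyond the scatter) in this assay. The estimate for compound 3 in this assay is 40 nM, within a range of 12 nM to 130 nM.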

Compound 3, half-maximal inhibitory concentration: 10 nM
Compound 3: the middle estimate sits 4.0-fold (0.60 log units) above what was measured; the whole stated range lies above it.
By their numbers in this assay, from the lowest: compounds 3 and 1 (each within the scatter of the next); then compound 2.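

In this assay, for the compounds shown here, the ester chain of this series takes a large change: 3-phenylpropyl in place of 1-nitroethyl, on a saturated chain carbon bound to an oxygen next to a carbonyl group, gives the first step that can be read directly (an 11-fold lower number from compound 2 to compound 3 (1.03 log units; beyond the scatter)). This position therefore accepts a longer chain ending in a six-membered aromatic ring of carbon only, and the 1-nitroethyl group is not required for a low number here. Nothing measured bears on the cause of this step.

Which part of the entering group goes with the lower number remains open, as 3-phenylpropyl differs from 1-nitroethyl in both chain length and the aromatic ring. A plain butyl chain, a benzyl group or a chain ending in an amine at the same place would separate these readings.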